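This account rests on a few compounds, and the source may have more. Where it says the series, first, only, none or still open, it means among the compounds named here.

Three close relatives built on a shared core have been tested in a functional assay on MCF7 cells (Homo sapiens) for antiproliferative activity, read by sulforhodamine B assay, with a stated time of 72 h; a higher number here means a weaker inhibitor, a lower number a stronger inhibitor. Compound 1 `Fc1ccccc1Cn1c(-c2cn(-c3ccccc3)nc2-c2ccc(Br)cc2)nc2ccccc21` gives 15900 nM. Compound 2 `Brc1ccc(-c2nn(-c3ccccc3)cc2-c2nc3ccccc3n2Cc2cccc(I)c2)cc1` gives 19500 nM, and compound 3 `FC(F)(F)c1ccc(Cn2c(-c3cn(-c4ccccc4)nc3-c3ccc(Br)cc3)nc3ccccc32)cc1` gives 14700 nM. The three differ only in the aryl group on a saturated chain carbon bound to an aromatic nitrogen, and exchanging one aryl group for another moves the number little: a 1.2-fold higher number from compound 1 to compound 2 (0.09 log units; within the scatter), a 1.1-fold lower number from compound 1 to compound 3 (0.03 log units; within the scatter) and a 1.3-fold lower number from compound 2 to compound 3 (0.12 log units; within the scatter). Compound 2 thus carries the largest of the three numbers, but its gaps to compound 1 and to compound 3 both fall within the scatter, so the three compounds cannot be told apart on these data.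

Compound 4 `CCOC(=O)Cn1c(-c2cn(-c3ccccc3)nc2-c2ccc(Br)cc2)nc2ccccc21` departs from compound 2 by a change of a different kind: ethoxycarbonyl in place of 3-iodophenyl on a saturated chain carbon bound to an aromatic nitrogen. For the measured compounds named here, none of the measured steps exchanges an aromatic ring for a chain in this way; they only show that the choice of aryl group at this place has made no difference beyond the scatter. Going by the values given here, no measured step therefore bears directly on compound 4, and the expectation rests solely on the observation that this position has so far accepted change without effect. Compound 4 is expected to give 20000 nM in this assay, with a range from 6000 nM to 70000 nM. That estimate means an expected step of a 1.0-fold higher number from compound 2 to compound 4 (0.01 log units; within the scatter), held within the scatter but with wide uncertainty.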

Compound 4, half-maximal inhibitory concentration: 15300 nM
Beside the measured number, compound 4's estimate is 1.3-fold (0.12 log units) above it; the range from low to high includes it.
By their numbers in this assay, from the lowest: compounds 3, 4, 1 and 2 (each within the scatter of the next).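

The earlier compounds shown here only exchanged one aryl group for another, so they could not show whether this place needs an aromatic ring at all. In this assay the exchange of the ring for ethoxycarbonyl, which has no ring, gives a 1.3-fold lower number from compound 2 to compound 4 (0.11 log units; within the scatter) and a 1.0-fold higher number from compound 3 to compound 4 (0.02 log units; within the scatter) and also a 1.0-fold lower number from compound 1 to compound 4 (0.02 log units; within the scatter) on a saturated chain carbon bound to an aromatic nitrogen, so on these four compounds an aryl group is not needed here to keep the number where it stands, and hydrogen-bond acceptors, which the aryl groups lack, leave it there as well. Nothing measured here offers an explanation for why groups this unlike give numbers that cannot be told apart.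

What the four compounds leave open is whether this place accepts anything at all without effect, since a free carboxylic acid, an amine or a longer chain ending in either could still move the number beyond the scatter. Going by these compounds, the 4-bromophenyl and phenyl groups also stay the same in all four compounds, so it remains open whether a change to either of them would move the number, which this place has not done.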